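This account rests on a few compounds, and the source may have more. Where it says the series, first, only, none or still open, it means among the compounds named here.

Measured so far in a functional assay on HeLa cells (Homo sapiens) for cytotoxicity, read by sulforhodamine B assay, with a stated time of 48 h; on this read-out higher numbers stand for weaker inhibition and lower numbers for stronger inhibition:
Compound 1 `C=CCOc1ccc(Br)cc1C(=O)c1cccnc1`: 96000 nM
Compound 2 `C=CCOc1ccc(C)cc1C(=O)c1cccnc1`: 94000 nM

On these numbers, compound 2 stands within the scatter of compound 1. Compound 3 `C=CCOc1ccccc1C(=O)c1cccnc1` differs from compound 2 as follows: hydrogen in place of methyl on an aromatic carbon. That is hydrogen in place of methyl on an aromatic carbon, at the same place as the methyl in place of bromo change that links compound 1 to compound 2. Within the data shown here, no step beyond the scatter, in either direction, is expected in this assay, because the only measured step was a 1.0-fold lower number from compound 1 to compound 2 (0.01 log units; within the scatter). The expected step is a 1.0-fold higher number from compound 2 to compound 3 (0.00 log units; within the scatter). Compound 3 is estimated at 95000 nM, with an expected range from 55000 nM to 160000 nM.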

Compound 3, half-maximal inhibitory concentration: > 100000 nM
Compound 3: no number, only a limit (the forecaster's own chance of this, stated with the estimate: 30%); at least 1.0-fold (0.02 log units) between middle value and limit.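

In this assay compound 3, with hydrogen para to the allyloxy group, gives only a limit, > 100000 nM, and not a number. The record shows an at least 1.0-fold higher number from compound 2 to compound 3 (0.02 log units; that floor lies within the scatter) and an at least 1.0-fold higher number from compound 1 to compound 3 (0.01 log units; that floor lies within the scatter), so this position now has three substituents, yet neither floor separates hydrogen from methyl or bromo. The true size of either step stays unknown because of the limit: the limit of > 100000 nM in this assay, at which 1 of the 3 values shown sits.

The compounds shown leave open whether an amine, a carboxylic acid or a longer chain at this position would give a lower number.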